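The compounds below may be only part of what the source reports. "The series", "measured", "known", "first", "only" and "open" are said of these compounds alone.

Measured compounds:
compound 1, `CCOC(=O)c1[nH]c(=O)c(C#N)cc1C(=O)c1ccc(OC)cc1`: 259000 nM
compound 2, `CCOC(=O)c1[nH]c(=O)c(C#N)cc1C(=O)c1ccc(Cl)cc1`: 218000 nM
compound 3, `O=C(c1ccc([N+](=O)[O-])cc1)c1cc(C(=O)O)c(=O)[nH]c1C(=O)O`: 439000 nM

Three compounds sharing a core have been run in an ADME assay on L929 cells (Mus musculus) for cytotoxicity, read by MTT assay, with a stated time of 72 h; on this read-out higher numbers stand for lower toxicity in this test and lower numbers for higher toxicity in this test. Compound 1 gives 259000 nM, compound 2 gives 218000 nM and compound 3 gives 439000 nM. Compound 2 shows the lowest of the three numbers, but its gap to compound 1 and its gap to compound 3 are both within the scatter, so no ordering among them can be claimed.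

Among the compounds with values here, the single step within the measured set is a 1.2-fold lower number from compound 1 to compound 2 (0.07 log units; within the scatter). That step, chloro in place of methoxy on an aromatic carbon, is the only one that bears on the change now in question.

Compound 4, `CCOC(=O)c1[nH]c(=O)c(C#N)cc1C(=O)c1ccc(Br)cc1`, differs from compound 2 by bromo in place of chloro on an aromatic carbon. Within the data shown here, the one halogen exchange already on record in this assay left the read-out within the scatter, and a second halogen exchange at the same place is expected to do the same. The step of a 1.0-fold higher number from compound 2 to compound 4 (0.00 log units; within the scatter) is therefore expected to stay within the scatter. Compound 4 is estimated at 220000 nM in this assay, with a range from 110000 nM to 440000 nM.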

Compound 4, half-maximal cytotoxic concentration: 242000 nM
Compound 4: middle estimate off by 1.1-fold (0.04 log units), on the low side; the measured number falls inside the stated range.
By their numbers in this assay, from the lowest: compounds 2, 4, 1 and 3 (each within the scatter of the next).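

In this assay the change from 4-chlorophenyl to 4-bromophenyl gives a 1.1-fold higher number from compound 2 to compound 4 (0.05 log units; within the scatter), so this read-out does not separate the two halogens on this aromatic carbon, para to a large group. Bromo in place of methoxy gives a 1.1-fold lower number from compound 1 to compound 4 (0.03 log units; within the scatter), which places methoxy, chloro and bromo at this position within the scatter of one another in the compounds shown. No measured evidence bearing on this result is available.

From the compounds shown here alone, it remains open whether a group of another kind at this position, such as an amine or a hydroxyl, would take the number beyond the scatter. Also open, going by these compounds, is whether a longer chain in place of the ethyl ester would do so with the halogens held constant.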